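This account rests on a few compounds, and the source may have more. Where it says the series, first, only, none or still open, it means among the compounds named here.

Measured in a functional assay on SK-MEL-5 cells (Homo sapiens) for cytotoxicity, read by sulforhodamine B assay, with a stated time of 48 h (a higher number here means a weaker inhibitor of growth, a lower number a stronger inhibitor of growth), so far:
compound 1, `ClCc1ccc(Cn2cnc3c(Cl)ncnc32)cc1`: 3230 nM
compound 2, `ClCc1ccccc1Cn1cnc2c(Cl)nc(Cl)nc21`: 420 nM
compound 3, `ClCc1cccc(Cn2cnc3c(Cl)ncnc32)c1`: 2290 nM

Compound 1 gives the highest of the three numbers in this assay. Compound 3 lies within the scatter of compound 1, so the two cannot be ordered. Compound 2 sits beyond the scatter, a clearly lower number than compound 1. Among the compounds with values here, no pair among the measured compounds differs in only one place, so no single step is available.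

Compound 4, `ClCc1ccc(Cn2cnc3c(Cl)nc(Cl)nc32)cc1`, is to be measured in this assay. It differs from compound 1 by chloro in place of hydrogen on an aromatic carbon. Within the data shown here, the only measured compound carrying this second chloro on the shared core is compound 2, which also differs from compound 1 in the arrangement of the chloromethyl group, so the two changes cannot be separated. Still, compound 2 with 420 nM suggests the added chloro is compatible with a lower number. The step from compound 1 to compound 4 is expected to be a drop beyond the scatter, a 3.6-fold lower number from compound 1 to compound 4 (0.55 log units; beyond the scatter). Compound 4 is estimated at 900 nM, with a range from 250 nM to 3000 nM.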

Compound 4, concentration for 50% growth inhibition: 6460 nM
For compound 4 the middle estimate is 7.2-fold (0.86 log units) below the measured one, outside the stated range (above it).
By their numbers in this assay, from the lowest: compound 2; then compounds 3, 1 and 4 (each within the scatter of the next, the first and the last beyond it).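

In this assay chloro in place of hydrogen on an aromatic carbon between two ring nitrogen atoms gives a 2.0-fold higher number from compound 1 to compound 4 (0.30 log units; within the scatter) and so leaves no readable change at this position. This single-place step offers no support for this chloro alone lowering the number. No measured evidence bears on the result.

Open, on these data alone, is whether an amine or a methoxy group at this position would move the number beyond the scatter. Also open, as far as these compounds go, is how the place of the chloromethyl group acts when this chloro is held fixed.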